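Replacing the Selenol on the Core with Methylsulfanyl

The compounds below may be only part of what the source reports. "The series", "measured", "known", "first", "only" and "open" are said of these compounds alone.

Measured compounds:
compound 1, `CSc1ccc(CNc2nc([SeH])nc3ccccc23)cc1`: 48100 nM
compound 2, `[SeH]c1nc(NCc2ccccc2)c2ccccc2n1`: a limit, > 100000 nM

In a functional assay on MCF7 cells (Homo sapiens) for cytotoxicity, read by MTT assay, with a stated time of 72 h (a lower number here means a stronger inhibitor of growth, a higher number a weaker inhibitor of growth), compound 1 gives 48100 nM. Among the measured compounds shown here, this is the only number known; the other value is a limit. For compound 2 the assay returns only the limit > 100000 nM, and the limit of > 100000 nM in this assay, at which 1 of the 2 values shown sits, marks that one of the two values sits there. Accordingly, an at least 2.0-fold higher number from compound 1 to compound 2 (0.31 log units; beyond the scatter) is known only as a lower bound on its size.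

Compound 3, `CSc1ccc(CNc2nc(SC)nc3ccccc23)cc1`, is the next compound. It differs from compound 1 by a group of 2 heavy atoms (1 carbon, 1 sulfur; no ring) in place of one selenium atom, on an aromatic carbon. For the measured compounds named here, no measured step touches this position: the one measured step removes a group elsewhere, so no known pair speaks to what this exchange does. With nothing pointing either way, compound 3 is expected to show no step beyond the scatter in this assay, that is a 1.0-fold higher number from compound 1 to compound 3 (0.02 log units; within the scatter). The estimate for compound 3 is 50000 nM, with a range from 15000 nM to 150000 nM.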

Compound 3, concentration for 50% growth inhibition: 47300 nM
Compound 3: the middle estimate sits 1.1-fold (0.02 log units) above what was measured; the measured number falls inside the stated range.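

The exchange on the aromatic carbon between two ring nitrogen atoms gives a 1.0-fold lower number from compound 1 to compound 3 (0.01 log units; within the scatter) in this assay. Among the compounds shown here, the earlier step concerned only the methylsulfanyl on the other ring, so this is the first reading at this position: the selenol of compound 1 can give way to methylsulfanyl with no measurable change in growth inhibition, and compound 3 holds no selenium at all. The compounds shown offer no measured property that would explain this sameness.

As far as these compounds go, whether an amine, a carboxylic acid or a longer chain at this position would also leave the number unchanged remains open. So does whether hydrogen in place of the other methylsulfanyl would weaken growth inhibition in a compound carrying methylsulfanyl on the core, as it does from compound 1 to compound 2 with the selenol there.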